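From Compound 1 to Compound 4: a Phenyl Exchange

A few compounds are considered here, and "the series" means these few. Any claim that something is new, unique, unknown or untested is made for them only; others in the source may bear on it.

Compound 1 `O=C(Nc1cc2cc[nH]c(=O)c2cc1Cl)C1CNCC1c1ccc(Cl)cc1Cl` has no result in a functional assay on aorta (Rattus norvegicus) for inhibition (a lower number here means a stronger inhibitor, a higher number a weaker inhibitor), where compound 1 stands as "not determined" (no result reported); its standing among the measured compounds therefore cannot be given. Compound 2 `O=C(Nc1cc2cc[nH]c(=O)c2cc1Cl)[C@@H]1CCCNC1` gives 550 nM in this assay, and compound 3 `CN1CCC(C(=O)Nc2cc3cc[nH]c(=O)c3cc2Cl)CC1` gives 250 nM. In the one shown step, a 2.2-fold lower number from compound 2 to compound 3 (0.34 log units; beyond the scatter). Compound 4 `O=C(Nc1cc2cc[nH]c(=O)c2cc1Cl)C1CNCC1c1cccc(Br)c1` differs from compound 1 in one place: 3-bromophenyl in place of 2,4-dichlorophenyl on a saturated ring carbon. Among the measured compounds shown here, no measured step touches this part of the molecule; the single step that exists concerns the saturated ring on the carbonyl carbon, not the aromatic group attached to it. The data thus give no direction for the change, and compound 1 itself lacks a number to step from. With the two measured values as the only anchor, compound 4 is expected to give about 400 nM in this assay, within a wide range from 80 nM to 2500 nM.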

Compound 4, half-maximal inhibitory concentration: 63 nM
Beside the measured number, compound 4's estimate is 6.3-fold (0.80 log units) above it; the whole stated range lies above it.
By their numbers in this assay, from the lowest: compound 4; then compound 3; then compound 2.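

No new step can be read between compound 1 and compound 4 in this assay. The compounds shown leave open what the exchange of 2,4-dichlorophenyl for 3-bromophenyl does in this assay. Nothing available explains the value of compound 4.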